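A few compounds are considered here, and "the series" means these few. Any claim that something is new, unique, unknown or untested is made for them only; others in the source may bear on it.

In an ADME assay on cells (Hepatocyte, Homo sapiens) for metabolic stability (on this read-out lower numbers stand for slow clearance and higher numbers for fast clearance), compound 1 `COc1cc(F)ccc1-c1ccnc2[nH]c(C3CCN(CC(=O)N(C)C)CC3)cc12` gives 4.9 uL/min and compound 2 `CC(C)n1cc(-c2ccnc3[nH]c(C4CCN(CC(=O)N5CCCCC5)CC4)cc23)ccc1=O` gives 8 uL/min. Compound 3 `CC(C)n1cc(-c2ccnc3[nH]c(C4CCN(CC(=O)N(C)C)CC4)cc23)ccc1=O` gives < 1 uL/min, which is a limit of the assay (the limit of < 1 uL/min in this assay, at which 1 of the 3 values shown sits). Both measured steps, an at least 4.9-fold lower number from compound 1 to compound 3 (0.69 log units; beyond the scatter) and an at least 8.0-fold lower number from compound 2 to compound 3 (0.90 log units; beyond the scatter), end at compound 3, so compound 3 stands at the lowest end of the numbers shown. Compound 4 `CN(C)C(=O)CN1CCC(c2cc3c(-c4ccc(=O)n(C5CCC5)c4)ccnc3[nH]2)CC1` differs from compound 3 by cyclobutyl in place of isopropyl on an aromatic nitrogen. Neither measured step alters the group on the aromatic nitrogen, so neither bears directly on this change, and with compound 3 at a limit the step is expected to be small, an at least 1.2-fold higher number from compound 3 to compound 4 (0.07 log units; that floor lies within the scatter), with no direction beyond the scatter. Compound 4 is therefore expected to give 1.2 uL/min in this assay, within a range from 0.5 uL/min to 3.5 uL/min.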

Compound 4, intrinsic clearance in a liver preparation (reported as CLH), per the amount of preparation that the assay uses in the Hepatocyte assay: < 1 uL/min
Compound 4: only a limit was reported; the forecaster's own chance of this, stated with the estimate: 40%; at least 1.2-fold (0.07 log units) between middle value and limit.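

Among these compounds, in the Hepatocyte assay, compound 3 and compound 4 both stand at a limit of the assay, so no step between them can be read. In a physicochemical assay for solubility, in phosphate buffer, at pH 7.4 (on this read-out lower numbers stand for lower solubility and higher numbers for higher solubility), compound 3 gives 110000 nM. In the physicochemical assay compound 4 gives > 1000000 nM, which is a limit of the assay. The compounds shown leave open whether cyclobutyl and isopropyl on the aromatic nitrogen differ at all in clearance.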